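Pyridin-3-yl carbonyl on the 3-chlorophenyl sulfonamide scaffold

A few compounds are considered here, and "the series" means these few. Any claim that something is new, unique, unknown or untested is made for them only; others in the source may bear on it.

Two members of this sulfonamide-benzamide series have numbers. Compound 1 `O=C(NCc1ccc(CNS(=O)(=O)c2ccccc2Cl)cc1)c1cccnc1` in an assay on MDA-MB-231 cells for displacement of a labelled ligand from C-X-C chemokine receptor type 4 (Homo sapiens), read by fluorescence and microscopy, with stated times of 10 min and 30 min (on this read-out higher numbers stand for an effect only at larger amounts of compound and lower numbers for an effect already at smaller amounts), gives 100 nM. Compound 2 `Cc1ccccc1C(=O)NCc1ccc(CNS(=O)(=O)c2cccc(Cl)c2)cc1` in this assay gives 100 nM, which is level with compound 1 at the digits shown; the two values lie within the scatter, so no order between them can be read.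

The next compound is compound 3 `O=C(NCc1ccc(CNS(=O)(=O)c2cccc(Cl)c2)cc1)c1cccnc1`, still to be measured in this assay. Relative to compound 2 the change is pyridin-3-yl in place of 2-methylphenyl on a carbonyl carbon. The (pyridin-3-yl)carbonyl that enters is the same group found in compound 1, which gives 100 nM, so the two measured points carry no sign that either aryl carbonyl is favoured.

Among the compounds with values here, no measured step covers this change. The expected step from compound 2 to compound 3 in this assay is no change at the digits printed from compound 2 to compound 3 (within the scatter), meaning none beyond the scatter, because compound 2 gives 100 nM and compound 1 gives 100 nM. Compound 3 in this assay is therefore estimated at 100 nM, with a range from 50 nM to 200 nM.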

Compound 3, effective concentration (reported as EC, without a stated level of effect): 100 nM
Beside the measured number, compound 3's estimate shows no gap at the digits printed; the range from low to high includes it.
By their numbers in this assay, from the lowest: compounds 1, 2 and 3 (each within the scatter of the next).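

In this assay the place on a carbonyl carbon now has a direct reading: pyridin-3-yl in place of 2-methylphenyl, which brings in one hydrogen-bond acceptor and removes the methyl-bearing carbon ring, gives no change at the digits printed from compound 2 to compound 3 (within the scatter) on the 3-chlorophenyl sulfonamide. The second place also gets its first reading with the (pyridin-3-yl)carbonyl held constant: 3-chlorophenyl in place of 2-chlorophenyl on a sulfonyl sulfur gives no change at the digits printed from compound 1 to compound 3 (within the scatter) and so shows no separation between the two chlorophenyl groups. Nothing available accounts for either flat step.

Going by these compounds, with only these aryl groups and chlorophenyl isomers in view, it remains open whether either place can move the read-out at all, since none of the three compounds separates from the others. A piperidine, a carboxylic acid or a longer alkyl chain on the carbonyl carbon, and a trifluoromethyl group or a methoxy group in place of the chlorine, would test that sensitivity, and their outcome cannot be inferred from these level values.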